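Methoxyphenyl placement in a bromophenyl-thiazole aminothiadiazole series

The source may report more compounds than this note shows. Statements on the series, on what has been measured and on what is new or still open speak of the compounds shown alone.

Measured compounds:
compound 1, `COc1ccccc1Nc1nnc(Nc2nc(-c3ccc(Br)cc3)cs2)s1`: 300 mg/kg
compound 2, `COc1ccc(Nc2nnc(Nc3nc(-c4ccc(Br)cc4)cs3)s2)cc1`: 30 mg/kg
compound 3, `COc1ccccc1Nc1nnc(Nc2nc(-c3ccccc3)cs2)s1`: 100 mg/kg

Of the compounds shown here, three have been tested in a functional assay on the whole organism (strain albino) with Mus musculus as the target, in the maximal electroshock model, with a stated time of 0.5 h; a lower number here means that less compound is needed, a higher number that more compound is needed for the effect. Compound 1 `COc1ccccc1Nc1nnc(Nc2nc(-c3ccc(Br)cc3)cs2)s1` gives 300 mg/kg in this assay. Compound 2 `COc1ccc(Nc2nnc(Nc3nc(-c4ccc(Br)cc4)cs3)s2)cc1` differs from compound 1 in one place, (4-methoxyphenyl in place of 2-methoxyphenyl on a nitrogen on an aromatic ring). In this assay compound 2 gives 30 mg/kg; this is the step of a 10-fold lower number from compound 1 to compound 2 (1.00 log units; beyond the scatter). Compound 3 `COc1ccccc1Nc1nnc(Nc2nc(-c3ccccc3)cs2)s1` differs from compound 1 in a different place, (hydrogen in place of bromo on an aromatic carbon). In this assay compound 3 gives 100 mg/kg, which is the step of a 3.0-fold lower number from compound 1 to compound 3 (0.48 log units; beyond the scatter). Among the three, compound 2 needs the least compound for the effect, and both steps away from compound 1 lie beyond the scatter.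

Compound 4 `COc1ccc(Nc2nnc(Nc3nc(-c4ccccc4)cs3)s2)cc1` has not yet been measured in this assay. It differs from compound 3 by 4-methoxyphenyl in place of 2-methoxyphenyl on a nitrogen on an aromatic ring. This is the same change that separates compound 1 from compound 2, made here on the core of compound 3, whose difference from the core of compound 1 is the one counted above as hydrogen in place of bromo on an aromatic carbon. The change has been seen once, as the step of a 10-fold lower number from compound 1 to compound 2 (1.00 log units; beyond the scatter), and the place of the change is the same word for word in both pairs. The expectation for compound 4 therefore rests on that single step applied to the value of compound 3, with the step from compound 3 to compound 4 estimated as a 10-fold lower number from compound 3 to compound 4 (1.00 log units; beyond the scatter). Compound 4 is accordingly expected to give about 10 mg/kg in this assay, within an estimated range from 3 mg/kg to 30 mg/kg, on the basis of 100 mg/kg for compound 3 and the step of a 10-fold lower number from compound 1 to compound 2 (1.00 log units; beyond the scatter).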

Compound 4, minimum effective dose: 100 mg/kg
The estimate for compound 4 lay 10-fold (1.00 log units) below the measured number; measured number outside the range, above it.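

In this assay the change from 2-methoxyphenyl to 4-methoxyphenyl does not carry over from the core of compound 1 to the core of compound 3, where it gives no change at the digits printed from compound 3 to compound 4 (within the scatter) and so departs from its earlier step on the bromo core: the same change on two cores in this assay, a 10-fold lower number (1.00 log units; beyond the scatter) from compound 1 to compound 2 and no change at the digits printed (within the scatter) from compound 3 to compound 4, 10-fold (1.00 log units) apart, beyond the scatter of two such steps. Seen from the other side, hydrogen in place of bromo also depends on the partner group, giving a 3.3-fold higher number from compound 2 to compound 4 (0.52 log units; beyond the scatter) with 4-methoxyphenyl present, opposite in direction to the earlier step with 2-methoxyphenyl: the same change on two cores in this assay, a 3.0-fold lower number (0.48 log units; beyond the scatter) from compound 1 to compound 3 and a 3.3-fold higher number (0.52 log units; beyond the scatter) from compound 2 to compound 4, 10-fold (1.00 log units) apart, beyond the scatter of two such steps. Both comparisons rest on the same four compounds, so they are one result seen from two sides: the two changes do not add here, but this single square shows neither why they do not add nor how any other core would behave.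

Open, going by these compounds, is whether the lower number with 4-methoxyphenyl needs bromo itself or would also appear with chloro, methyl or a nitrile in its place. Equally open, on these data alone, is how ethoxy or an amine in place of the methoxy group would behave on either core.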